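Trimming isopropyl to ethyl on the shared core

A few compounds are considered here, and "the series" means these few. Any claim that something is new, unique, unknown or untested is made for them only; others in the source may bear on it.

Measured so far:
- compound 1 `CC(C)c1ncn2c(Nc3cc[nH]n3)nccc12`: > 48000 nM
- compound 2 `C=CCn1ncc2c(C)nc(CCC)n2c1=O`: 40000 nM
- compound 3 `CCCc1ncc2c(C)cnc(Nc3cc[nH]n3)n12`: 39000 nM

In a functional assay for inhibition, with Homo sapiens as the target (on this read-out higher numbers stand for weaker inhibition and lower numbers for stronger inhibition), compound 1 gives only > 48000 nM, which is a limit of the assay and not a number (the limit of > 48000 nM in this assay, at which 1 of the 3 values shown sits). Within the data shown here, compound 2 gives 40000 nM and compound 3 gives 39000 nM in this assay; no step between measured compounds is given, so the three values stand only side by side.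

Compound 4 `CCc1ncn2c(Nc3cc[nH]n3)nccc12` is not yet measured. It differs from compound 1 by hydrogen in place of methyl on a saturated chain carbon bound to an aromatic carbon and a saturated chain carbon. Among the measured compounds shown here, no measured step bears on such a change, so nothing beyond the scatter is expected in this assay. The expected step is a step that the limit leaves unreadable from compound 1 to compound 4. Compound 4 is therefore estimated at 50000 nM, within 20000 nM to 150000 nM, and most likely again reported only as a limit.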

Compound 4, half-maximal inhibitory concentration: 36000 nM
Beside the measured number, compound 4's estimate is 1.4-fold (0.14 log units) above it; the range from low to high includes it.
By their numbers in this assay, from the lowest: compounds 4, 3 and 2 (each within the scatter of the next). At a limit, above all of these: compound 1.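

On the shared core, an at least 1.3-fold lower number from compound 1 to compound 4 (0.12 log units; that floor lies within the scatter) in this assay, so trimming isopropyl to ethyl gives this position a reading that is a number rather than a limit. Compound 1 stands at a limit, and the true size of the step cannot be read because of it: the limit of > 48000 nM in this assay, at which 1 of the 4 values shown sits. The change therefore shows no loss of inhibition on going to ethyl, but no clear gain either.

Still open, going by these compounds, is whether a longer chain such as butyl, an amine or a carboxylic acid at this position would move the value beyond the scatter.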